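The source may hold more compounds than are shown below. What is called first, only, known or untested is meant among the compounds shown, and "the series" means these compounds.

Measured compounds:
compound 1, `COc1ccc(C(=O)c2cc(OC)c(OC)c(OC)c2)cc1N`, 2100 nM in a functional assay on DU-145 cells (Homo sapiens) for cytotoxicity, read by MTT assay, with a stated time of 72 h; a higher number here means a weaker inhibitor, a lower number a stronger inhibitor
compound 2, `COc1ccc(/C=C/C(=O)Nc2cc(C(=O)c3cc(OC)c(OC)c(OC)c3)cc(OC)c2OC)cc1OC`, 7800 nM
compound 3, `COc1ccc(/C=C/C(=O)Nc2cc(C(=O)c3cc(OC)c(OC)c(OC)c3)cc(OC)c2OC)cc1`, 10400 nM

Going by the values given here, compound 3 stands with the highest number of the three in this assay; the nearest is compound 2, and the single measured step, a 1.3-fold higher number from compound 2 to compound 3 (0.12 log units; within the scatter), stays within the scatter, so the two are not distinguished. The furthest is compound 1, whose value lies well below that of compound 3.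

Compound 4, `COc1cc(C(=O)c2cc(OC)c(OC)c(OC)c2)cc(N)c1OC`, differs from compound 3 by hydrogen in place of (2-(4-methoxyphenyl)ethenyl)carbonyl on a nitrogen on an aromatic ring. Among the compounds with values here, no measured step covers this change directly. Within the data shown here, the closest guide is the pair of compound 1 and compound 2, where the amine of compound 1 gives 2100 nM and the amide of compound 2 gives 7800 nM, although these two also differ in their methoxy pattern and no step for that pair is given. On that basis compound 4 is expected to return a lower number than compound 3, with an estimated step of a 3.5-fold lower number from compound 3 to compound 4 (0.54 log units; beyond the scatter). Compound 4 is therefore estimated at 3000 nM, with a range from 1000 nM to 9000 nM.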

Compound 4, half-maximal inhibitory concentration: 10000 nM
For compound 4 the middle estimate is 3.3-fold (0.52 log units) below the measured one; measured number above the stated range.
By their numbers in this assay, from the lowest: compound 1; then compounds 2, 4 and 3 (each within the scatter of the next).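

In this assay the nitrogen on the aromatic ring of compound 3 can lose its (2-(4-methoxyphenyl)ethenyl)carbonyl for a hydrogen without a change beyond the scatter (a 1.0-fold lower number from compound 3 to compound 4 (0.02 log units; within the scatter)), so that acyl group and the free amine are not told apart on this core. The methoxy on the aromatic carbon, which earlier made no measurable difference on the amide, separates the two amines (a 4.8-fold higher number from compound 1 to compound 4 (0.68 log units; beyond the scatter)). The reading of this one change therefore depends on what the nitrogen carries: the same change on two cores in this assay, a 1.3-fold higher number (0.12 log units; within the scatter) from compound 2 to compound 3 and a 4.8-fold lower number (0.68 log units; beyond the scatter) from compound 4 to compound 1, 6.3-fold (0.80 log units) apart, beyond the scatter of two such steps.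

The compounds shown leave open whether a smaller acyl group such as acetyl on that nitrogen would fall with compound 3 and compound 4. They also leave open whether a hydroxyl or a fluorine in place of that methoxy would side with compound 1 or with compound 4.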